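Benzylamino for piperidin-1-yl: working notes on compound 3

A few compounds are considered here, and "the series" means these few. Any claim that something is new, unique, unknown or untested is made for them only; others in the source may bear on it.

Compound 1 `CCCSc1nc(N2CCCCC2)c2nc(/C=C/C(=O)c3ccc(C)cc3)n(Cc3ccccc3)c2n1` carries a propylsulfanyl group and a piperidin-1-yl on the shared core. In a functional assay on THP-1 cells (Homo sapiens) for inhibition, read by MTT assay, with a stated time of 72 h (on this read-out lower numbers stand for stronger inhibition and higher numbers for weaker inhibition), compound 1 gives only a limit of the assay, > 32000 nM. Compound 2 `CCCSc1nc(Cl)c2c(n1)N(Cc1ccccc1)C(C(=O)NCCCc1ccccc1)N2` belongs to the same set, but in this assay compound 2 stands at "not determined" (no result reported). Within the data shown here, the set therefore holds no measured step between two numbers; what is known of compound 1 is the limit (the limit of > 32000 nM in this assay, at which 1 of the 2 values shown sits), so compound 1 cannot be placed against any other entry.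

Compound 3 `CCCSc1nc(NCc2ccccc2)c2nc(/C=C/C(=O)c3ccc(C)cc3)n(Cc3ccccc3)c2n1` is the next entry. Its change from compound 1 is benzylamino in place of piperidin-1-yl on an aromatic carbon. Among the measured compounds shown here, with compound 1 at a limit and no measured step in the set, the step of an at least 1.0-fold lower number from compound 1 to compound 3 (0.02 log units; that floor lies within the scatter) is expected to be small, none beyond the scatter in either direction, and the reading for compound 3 is as likely to be a limit again as a number. On that basis compound 3 is estimated at 30000 nM in this assay, with a range from 8000 nM to 100000 nM.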

Compound 3, half-maximal inhibitory concentration: > 32000 nM
Compound 3: a limit, no number; the forecaster's own chance of this, stated with the estimate: 60%; at least 1.0-fold (0.02 log units) between middle value and limit.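

Among these compounds, compound 3 and compound 1 both stand only at a limit in this assay, and no step between them can be read. The compounds shown leave open how far either compound lies from that limit, and whether benzylamino in place of piperidin-1-yl on the shared core changes the reading at all.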